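A Hydroxyl for a Methoxy in a Cytotoxicity Series

The source may report more compounds than this note shows. Statements on the series, on what has been measured and on what is new or still open speak of the compounds shown alone.

Two compounds of this set have been examined in a functional assay on NCI-H226 cells (Homo sapiens) for inhibition, read by sulforhodamine B assay, with a stated time of 48 h; on this read-out higher numbers stand for lower toxicity in this test and lower numbers for higher toxicity in this test. Compound 1 `O=C(Nc1cccc(-n2cc(-c3ccncc3)c(-c3ccc(Cl)c(O)c3)n2)c1)Nc1cccc(C(F)(F)F)c1` reached only the limit of the test, giving > 32500 nM. Compound 2 `COc1cc(-c2nn(-c3cccc(NC(=O)Nc4cc(C(F)(F)F)cc(C(F)(F)F)c4)c3)cc2-c2ccncc2)ccc1Cl` likewise stopped at a limit, giving > 50000 nM. Within the data shown here, both results are limits rather than numbers, and together they show only that neither compound reached the read-out within the range tested, as the two limit lines record the limit of > 32500 nM in this assay, at which 1 of the 2 values shown sits (the limit of > 50000 nM in this assay, at which 1 of the 2 values shown sits). Among the measured compounds shown here, no pair of measured compounds differs in a single place, so no measured step exists to lean on.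

Compound 3 `O=C(Nc1cccc(-n2cc(-c3ccncc3)c(-c3ccc(Cl)c(O)c3)n2)c1)Nc1cc(C(F)(F)F)cc(C(F)(F)F)c1` has not yet been measured. It differs from compound 2 by hydrogen in place of methyl on an oxygen on an aromatic ring, turning the 4-chloro-3-methoxyphenyl into 4-chloro-3-hydroxyphenyl. With compound 2 standing at a limit, nothing here points to a change beyond the scatter. The expected step is a number no higher from compound 2 to compound 3 (the limit leaves the size open), or nothing beyond the scatter. Compound 3 is accordingly estimated at 50000 nM, within 20000 nM to 100000 nM, and most likely it too will be reported only as a limit.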

Compound 3, concentration lethal to 50% of the cells: 37600 nM
Compound 3: middle estimate off by 1.3-fold (0.12 log units), on the high side, within the range that was stated.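

Changing methoxy to hydroxy on an oxygen on an aromatic ring gives an at least 1.3-fold lower number from compound 2 to compound 3 (0.12 log units; that floor lies within the scatter) in this assay, so this is a possible shift, but its printed floor does not establish a change beyond the scatter. Among these compounds, compound 3 gives 37600 nM, the first true number in this set, which shows that a compound carrying 4-chloro-3-hydroxyphenyl can be read as a number in this assay. Going by these compounds, compound 2 gives only a limit, > 50000 nM, so the real size of the step at this position stays unknown.

Compound 1 also gives only a limit, > 32500 nM, and the step made by trifluoromethyl in place of hydrogen on an aromatic carbon on the way to compound 3 cannot be read. Whether an ethoxy group on the same ring, or an amine in place of the hydroxy, would give a number in this assay is left open by the compounds shown.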